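The compounds below may be only part of what the source reports. "The series", "measured", "known", "first", "only" and "open" are said of these compounds alone.

In an ADME assay on HeLa cells (Homo sapiens) for cytotoxicity, read by crystal violet staining, with a stated time of 24 h (a lower number here means that less compound is needed, a higher number that more compound is needed for the effect), compound 1 `CCCNC(=O)c1ccc([N+](=O)[O-])o1` gives 150000 nM, compound 2 `CC(C)NC(=O)c1ccc([N+](=O)[O-])o1` gives 211000 nM and compound 3 `CCC(C)NC(=O)c1ccc([N+](=O)[O-])o1` gives 165000 nM. Compound 1 therefore stands level with the other two, and no order can be read among the three. Compound 4 `CCN(CC)CCCNC(=O)c1ccc([N+](=O)[O-])o1` departs from compound 1 by diethylamino in place of hydrogen on a saturated chain carbon, three bonds along the chain from an amide-type nitrogen. Within the data shown here, three measured steps bear on this position: a 1.4-fold higher number from compound 1 to compound 2 (0.15 log units; within the scatter), a 1.1-fold higher number from compound 1 to compound 3 (0.04 log units; within the scatter) and a 1.3-fold lower number from compound 2 to compound 3 (0.11 log units; within the scatter). All three are within the scatter, but they involve only a single added methyl or a rearranged chain. None of them introduces diethylamino, so the data offer no direction for so large an addition, and no step beyond the scatter can be predicted. For compound 4, the expected outcome is a 1.3-fold lower number from compound 1 to compound 4 (0.10 log units; within the scatter), with real uncertainty around it. Compound 4 is estimated at 120000 nM, with an expected range of 35000 nM to 300000 nM.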

Compound 4, half-maximal effective concentration: 100000 nM
Compound 4: middle estimate off by 1.2-fold (0.08 log units), on the high side; the measured number falls inside the stated range.
By their numbers in this assay, from the lowest: compounds 4, 1, 3 and 2 (each within the scatter of the next, the first and the last beyond it).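

Diethylamino in place of hydrogen on a saturated chain carbon, three bonds along the chain from an amide-type nitrogen, is a much larger change than the single methyl or rearranged chain of the earlier steps. Even so, in this assay it gives a 1.5-fold lower number from compound 1 to compound 4 (0.18 log units; within the scatter), so this position takes the whole group without a step beyond the scatter. Nothing at hand accounts for the number staying level with that of compound 1.

On these data alone, it remains open whether any group at this position can move the number beyond the scatter from compound 1, for example a carboxylic acid, a morpholine ring or a primary amine. Also open, as far as these compounds go, is whether a longer chain carrying the same diethylamino would stay level with compound 4.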